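From Compound 3 to Compound 4: Tolerance in Bovine Kidney Cells

The source may report more compounds than this note shows. Statements on the series, on what has been measured and on what is new or still open speak of the compounds shown alone.

Measured so far in an ADME assay on MDBK cells (Bos taurus) for cytotoxicity; a lower number here means that less compound is tolerated, a higher number that more compound is tolerated:
compound 1 `Fc1cccc(F)c1Cn1c(-c2c(F)cccc2F)nc2ccncc21`, 99000 nM
compound 2 `Cc1ccn(Cc2c(F)cccc2F)c2nc(-c3c(F)cccc3F)nc1-2`, > 100000 nM
compound 3 `Fc1cccc(F)c1Cn1ccc2nc(-c3ccccc3)nc-2c1`, > 100000 nM

Compound 1 `Fc1cccc(F)c1Cn1c(-c2c(F)cccc2F)nc2ccncc21` gives 99000 nM in this assay. Compound 2 `Cc1ccn(Cc2c(F)cccc2F)c2nc(-c3c(F)cccc3F)nc1-2` reaches only a limit of this assay, > 100000 nM. Compound 3 `Fc1cccc(F)c1Cn1ccc2nc(-c3ccccc3)nc-2c1` likewise reaches only a limit of this assay, > 100000 nM. Compound 3 therefore stands at the limit of > 100000 nM in this assay, at which 2 of the 3 values shown sit, together with compound 2, and the number for compound 1 lies within the usual scatter of that limit. Among these three compounds no single-point step has been measured, so no direction of change can be read from them.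

Compound 4 `Clc1cccc(Cn2ccc3nc(-c4ccccc4)nc-3c2)c1` has not yet been measured. It differs from compound 3 in one place: 3-chlorophenyl in place of 2,6-difluorophenyl on a saturated chain carbon bound to an aromatic nitrogen. Among the compounds with values here, no measured pair speaks to this change. Because compound 3 sits at the limit of > 100000 nM in this assay, at which 2 of the 3 values shown sit, and the other two compounds show the same picture, the expected step in this assay is none beyond the scatter, in neither direction. Compound 4 is expected to give 100000 nM, with a range from 45000 nM to 220000 nM. That estimate corresponds to an expected step of a number no higher from compound 3 to compound 4 (the limit leaves the size open), and the result is expected to be reported as a limit more often than as a number.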

Compound 4, half-maximal cytotoxic concentration: > 100000 nM
Compound 4 gave a limit, no number; the forecaster's own chance of this, stated with the estimate: 60%; the middle value lies on the limit itself.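

In this assay compound 4 gives > 100000 nM, which is a limit and not a number. Compound 3 also stands at a limit, so no step can be read from compound 3 to compound 4: the limit of > 100000 nM in this assay, at which 3 of the 4 values shown sit.

The compounds shown leave open whether 3-chlorophenyl in place of 2,6-difluorophenyl changes tolerance in this assay at all.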